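Lengthening the Sulfur Chain with a Hydroxyl Tail

The source may report more compounds than this note shows. Statements on the series, on what has been measured and on what is new or still open speak of the compounds shown alone.

Compound 1 `CC(C)c1n[nH]c2c(NCc3ccc(-c4ccccn4)cc3)nc(SCC(C)(C)O)nc12` and compound 2 `CSc1nc(NCc2ccc(-c3ccccn3)cc2)c2[nH]nc(C(C)C)c2n1` share one core and differ only on the saturated chain carbon bound to a sulfur. In a functional assay on HT cells (Homo sapiens) for antiproliferative activity, read by fluorescence, with a stated time of 72 h (a lower number here means a stronger inhibitor of growth, a higher number a weaker inhibitor of growth), compound 1 gives 507 nM, and compound 2 gives 783 nM. The two numbers sit within the scatter of each other: the step of a 1.5-fold higher number from compound 1 to compound 2 (0.19 log units; within the scatter) shows that removing the 1-hydroxy-1-methylethyl group there changed little. Compound 3 `CC(C)c1n[nH]c2c(NCc3ccc(-c4ccccn4)cc3)nc(SCCCO)nc12` takes the opposite direction at the same place: 2-hydroxyethyl in place of hydrogen on a saturated chain carbon bound to a sulfur. Because a 1.5-fold higher number from compound 1 to compound 2 (0.19 log units; within the scatter) was small, putting a hydroxyl-bearing chain back is expected to move the number little, perhaps a touch lower, so the step of a 1.3-fold lower number from compound 2 to compound 3 (0.12 log units; within the scatter) is the expected size. Compound 3 is therefore estimated at 600 nM in this assay, with a likely range from 300 nM to 1200 nM.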

Compound 3, concentration for 50% growth inhibition: 109 nM
Compound 3: the middle estimate sits 5.5-fold (0.74 log units) above what was measured; the measured number lies below the stated range.
By their numbers in this assay, from the lowest: compound 3; then compounds 1 and 2 (each within the scatter of the next).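

Putting 2-hydroxyethyl on the saturated chain carbon bound to a sulfur gives a 7.2-fold lower number from compound 2 to compound 3 (0.86 log units; beyond the scatter) in this assay and so shows that this place does respond to what it carries, which the pair of compound 1 and compound 2 alone did not reveal. Replacing 1-hydroxy-1-methylethyl with 2-hydroxyethyl gives a 4.7-fold lower number from compound 1 to compound 3 (0.67 log units; beyond the scatter) in the same test. A hydroxyl in the chain is therefore not enough by itself, since compound 1 also has one and still sits within the scatter of compound 2. Nothing available here explains this difference between the two chains.

As far as these compounds go, whether a longer chain ending in a hydroxyl, or an amine in its place, would lower the number further remains open. A plain propyl chain would show how much the hydroxyl itself contributes.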